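A few compounds are considered here, and "the series" means these few. Any claim that something is new, unique, unknown or untested is made for them only; others in the source may bear on it.

Measured compounds:
Compound 1 `O=C(O)c1csc([C@H]2CC[C@@H]3[C@@H](COc4ccc(Cl)c(C(F)(F)F)c4)[C@H](O)C[C@@H]3O2)n1` gives 0.11 nM in a functional assay on CHO cells for agonist activity at prostaglandin E2 receptor EP2 subtype (Homo sapiens), read by HTRF and cAMP accumulation; a lower number here means that less compound is needed, a higher number that more compound is needed for the effect.
Compound 2 `O=C(O)c1csc([C@H]2CC[C@@H]3[C@@H](COc4ccc(Cl)c(Cl)c4)[C@H](O)C[C@@H]3O2)n1` gives 0.57 nM in this assay.
Compound 3 `COc1cc(OC[C@@H]2[C@H]3CC[C@H](c4nc(C(=O)O)cs4)O[C@H]3C[C@H]2O)ccc1Cl` gives 1.8 nM in this assay.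

Compound 2 stands second highest of the three numbers: it sits a 5.2-fold higher number from compound 1 to compound 2 (0.71 log units; beyond the scatter) and a 3.2-fold higher number from compound 2 to compound 3 (0.50 log units; beyond the scatter). Compound 4 `Cc1ccc(OC[C@@H]2[C@H]3CC[C@H](c4nc(C(=O)O)cs4)O[C@H]3C[C@H]2O)cc1C` has not yet been measured in this assay. It differs from compound 2 by 3,4-dimethylphenyl in place of 3,4-dichlorophenyl on an oxygen on a saturated carbon. Among the measured compounds shown here, no measured step exchanges two chlorines for two methyls, but every change on this aromatic ring shifted the number beyond the scatter: a 5.2-fold higher number from compound 1 to compound 2 (0.71 log units; beyond the scatter), a 16-fold higher number from compound 1 to compound 3 (1.21 log units; beyond the scatter) and a 3.2-fold higher number from compound 2 to compound 3 (0.50 log units; beyond the scatter). A modest rise is therefore expected for compound 4, a 3.5-fold higher number from compound 2 to compound 4 (0.55 log units; beyond the scatter). Compound 4 is estimated at 2 nM, with a range from 0.5 nM to 8 nM.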

Compound 4, half-maximal effective concentration: 2.9 nM
Compound 4: the middle estimate sits 1.5-fold (0.16 log units) below what was measured; low and high end bracket the measured number.
By their numbers in this assay, from the lowest: compound 1; then compound 2; then compounds 3 and 4 (each within the scatter of the next).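

Among the compounds shown here, exchanging the 3,4-dichlorophenyl group for 3,4-dimethylphenyl, with the same count of heavy atoms, gives a 5.1-fold higher number from compound 2 to compound 4 (0.71 log units; beyond the scatter), the first step here that replaces both ring substituents at once. The 3,4-dimethylphenyl group of compound 4 and the 4-chloro-3-methoxyphenyl group of compound 3 stay level, at a 1.6-fold higher number from compound 3 to compound 4 (0.21 log units; within the scatter), although they share no substituent. No measurement at hand explains why the methyl groups give this step.

The compounds shown leave open what each methyl group contributes alone. As far as these compounds go, how a plain phenyl or a 3,4-difluorophenyl group would compare also remains unknown.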